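Cyclopentyl in Place of Methyl: An Expected Growth-Inhibition Value

This account rests on a few compounds, and the source may have more. Where it says the series, first, only, none or still open, it means among the compounds named here.

Compound 1, `COC(=O)c1nc(C)n(-c2ccccc2)n1`: > 100000 nM, a limit of the assay.
Compound 2, `COC(=O)c1nc(C)n(-c2ccc(OC)cc2)n1`: > 100000 nM, a limit of the assay.
Compound 3, `COC(=O)c1nc(C)n(-c2ccc(F)cc2)n1`: 11700 nM.

In a functional assay on NCI-H226 cells (Homo sapiens) for inhibition, read by MTT assay, with a stated time of 72 h (a higher number here means a weaker inhibitor of growth, a lower number a stronger inhibitor of growth), compound 1 reaches only the limit of the assay, > 100000 nM. Compound 2 likewise gives only the limit > 100000 nM. For the measured compounds named here, compound 3 is the one compound with a number, 11700 nM, so it stands alone among the three. The measured steps are an at least 8.5-fold lower number from compound 1 to compound 3 (0.93 log units; beyond the scatter) and an at least 8.5-fold lower number from compound 2 to compound 3 (0.93 log units; beyond the scatter), while a step that the two limits leave unreadable from compound 1 to compound 2 stays unreadable because both values sit at the limit of > 100000 nM in this assay, at which 2 of the 3 values shown sit.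

Compound 4, `COC(=O)c1nc(C2CCCC2)n(-c2ccc(F)cc2)n1`, differs from compound 3 in one place: cyclopentyl in place of methyl on an aromatic carbon. Going by the values given here, none of the measured steps bears on this position; all three concern the aryl ring, not the methyl. The shown data therefore give no direction for this change, and in this assay no step beyond the scatter is expected. The step of a 1.3-fold lower number from compound 3 to compound 4 (0.11 log units; within the scatter) is thus estimated as small. Compound 4 is expected to give 9000 nM, within 1500 nM to 50000 nM, with the range kept wide.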

Compound 4, concentration for 50% growth inhibition: 70500 nM
For compound 4 the middle estimate is 7.8-fold (0.89 log units) below the measured one; measured number above the stated range.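

The earlier compounds shown here changed only the aryl ring, so they said nothing about the aromatic carbon between two ring nitrogen atoms. Compound 4 shows that this place is not indifferent in this assay, with a 6.0-fold higher number from compound 3 to compound 4 (0.78 log units; beyond the scatter) when cyclopentyl replaces methyl, so that with the fluoro group kept on the aryl ring, cyclopentyl here goes with weaker growth inhibition than methyl. Nothing shown accounts for this step.

As far as these compounds go, with only methyl and cyclopentyl at this place, it remains open how a short chain such as ethyl, a cyclopropyl ring or an amine would read here. From the compounds shown here alone, it also remains open whether the change would run the same way with methoxy or hydrogen on the aryl ring, since compound 1 and compound 2 give only limits of the assay.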